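Removing a Fluorine from a Cytosine Nucleoside Analogue

The source may hold more compounds than are shown below. What is called first, only, known or untested is meant among the compounds shown, and "the series" means these compounds.

Three nucleoside analogues have been measured for their power to halt the growth of mouse lymphoma cells. Within the data shown here, compound 1 `Nc1ccn(C2OC(CO)C(Br)C2O)c(=O)n1` is the first; in a functional assay on L5178Y cells (Mus musculus) for antiproliferative activity (on this read-out higher numbers stand for weaker inhibition and lower numbers for stronger inhibition), compound 1 gives 0.03 ug/mL. Compound 3 `Nc1nc(=O)n(C2OC(CO)C(Br)C2O)cc1F` differs from it at one point, and in this assay compound 3 gives 0.06 ug/mL. Compound 2 `CS(=O)(=O)O[C@@H]1[C@@H](O)[C@H](n2cc(F)c(N)nc2=O)O[C@@H]1CO` shares its base with compound 3 but is built on a different sugar; in this assay compound 2 gives 0.05 ug/mL. The difference between the core of compound 2 and the core of compound 3 is not broken down here.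

The change from compound 3 to compound 1 is hydrogen in place of fluoro on an aromatic carbon. It produced a 2.0-fold lower number from compound 3 to compound 1 (0.30 log units; within the scatter).

Compound 4 `CS(=O)(=O)O[C@@H]1[C@@H](O)[C@H](n2ccc(N)nc2=O)O[C@@H]1CO` has not yet been measured. It arises from compound 2 by hydrogen in place of fluoro on an aromatic carbon. Among the measured compounds shown here, this is the same kind of change as the one from compound 3 to compound 1: the two places agree in every word except that in compound 2 the carbon is meta to a large group, whereas in compound 3 it is meta to a group of 9 heavy atoms. For the measured compounds named here, with only one earlier example, and that one within the scatter, the expectation rests on that single step and on compound 2 giving 0.05 ug/mL in this assay. The step expected here is a 1.7-fold lower number from compound 2 to compound 4 (0.22 log units; within the scatter), matching the earlier one in size. Compound 4 is therefore expected to give about 0.03 ug/mL in this assay, with a likely range from 0.015 ug/mL to 0.08 ug/mL.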

Compound 4, concentration for 50% inhibition: 0.07 ug/mL
Estimate against measurement, compound 4: 2.3-fold (0.37 log units) below, within the range that was stated.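

In this assay, putting hydrogen in place of fluoro on the core of compound 2 gives a 1.4-fold higher number from compound 2 to compound 4 (0.15 log units; within the scatter), a step that on its own cannot be told apart from repeat-measurement noise. Set beside the earlier step, the same swap does not carry over from one core to the other as a fixed amount, so the result on one core gives a poor guide to the result on the other: the same change on two cores in this assay, a 2.0-fold lower number (0.30 log units; within the scatter) from compound 3 to compound 1 and a 1.4-fold higher number (0.15 log units; within the scatter) from compound 2 to compound 4, 2.8-fold (0.45 log units) apart, beyond the scatter of two such steps This does not show that fluoro helps on one core and harms on the other, since each step alone lies within the scatter and only the gap between them lies beyond it; two cores also cannot show how the swap would behave on a third, and the data do not say what makes the two cores differ.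

The compounds shown carry only hydrogen or fluoro on that aromatic carbon, so it remains open how a chlorine atom or a methyl group there would compare on either core. As far as these compounds go, it also remains open whether the swap would behave differently on a sugar carrying an amine in place of the bromine or the methanesulfonate group.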